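The source may report more compounds than this note shows. Statements on the series, on what has been measured and on what is new or still open speak of the compounds shown alone.

Within the data shown here, compound 2 `COc1cccc(-c2c(C)nn(-c3nc(-c4ccc(Cl)c(Cl)c4)c(SC(C)C)s3)c2C(=O)O)c1` is one of only two compounds measured in a functional assay on BJAB cells (Homo sapiens) for antiproliferative activity, with a stated time of 4 days (on this read-out higher numbers stand for an effect only at larger amounts of compound and lower numbers for an effect already at smaller amounts), where compound 2 gives 14000 nM. The other, compound 1 `COc1cncc(-c2c(C)nn(-c3nc(-c4ccc(Cl)c(Cl)c4)c(SC(C)C)s3)c2C(=O)O)c1`, gives 21000 nM in this assay, and the step of a 1.5-fold lower number from compound 1 to compound 2 (0.18 log units; within the scatter) lies within the scatter, so the two cannot be told apart on these numbers. Compound 3 `Cc1nn(-c2nc(-c3ccc(Cl)c(Cl)c3)c(SC(C)C)s2)c(C(=O)O)c1-c1ccccc1` carries a single change from compound 2: hydrogen in place of methoxy on an aromatic carbon. Among the measured compounds shown here, no measured step removes a methoxy from this ring; the only known step, from compound 1 to compound 2, was small. Compound 3 is therefore expected to show a step of no change at the digits printed from compound 2 to compound 3 (within the scatter), with an estimated 14000 nM and a range from 6000 nM to 35000 nM.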

Compound 3, half-maximal effective concentration: 3000 nM
For compound 3 the middle estimate is 4.7-fold (0.67 log units) above the measured one; measured number below the stated range.
By their numbers in this assay, from the lowest: compound 3; then compounds 2 and 1 (each within the scatter of the next).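

In this assay, among these compounds, taking the methoxy off the ring gives a 4.7-fold lower number from compound 2 to compound 3 (0.67 log units; beyond the scatter), the first change at this position that goes beyond the scatter. Replacing the 5-methoxypyridin-3-yl group with plain phenyl gives a 7.0-fold lower number from compound 1 to compound 3 (0.85 log units; beyond the scatter), so the unsubstituted phenyl stands apart from both methoxy-bearing rings, which could not be told apart. No data at hand explain this step. Open, from the compounds shown here alone, is whether only methoxy gives the higher number or any group on this aromatic carbon would. A methyl, a chlorine or a hydroxyl there could separate these two readings.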